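This account rests on a few compounds, and the source may have more. Where it says the series, first, only, none or still open, it means among the compounds named here.

Compound 3 (`O=S(=O)(/C=C/c1ccc(Cl)cc1Cl)Cc1ccc(Nc2ncnc3ccc(Br)cc23)cc1`) gives 28000 nM in a functional assay on HT-29 cells (Homo sapiens); on this read-out lower numbers stand for stronger inhibition of growth and higher numbers for weaker inhibition of growth. That is within the scatter of compound 2 (`O=S(=O)(/C=C/c1ccc(Cl)c(Cl)c1)Cc1ccc(Nc2ncnc3ccc(Br)cc23)cc1`) at 27000 nM, while compound 1 (`O=S(=O)(/C=C/c1ccc(C(F)(F)F)cc1F)Cc1ccc(Nc2ncnc3ccccc23)cc1`) shows a higher number at 100000 nM. Compound 4 (`O=S(=O)(/C=C/c1ccc(C(F)(F)F)cc1F)Cc1ccc(Nc2ncnc3ccc(Br)cc23)cc1`) differs from compound 3 by 2-fluoro-4-(trifluoromethyl)phenyl in place of 2,4-dichlorophenyl on a double-bonded chain carbon bound to a double-bonded chain carbon. Among the compounds with values here, the one measured step at this place, 2,4-dichlorophenyl in place of 3,4-dichlorophenyl, is a 1.0-fold higher number from compound 2 to compound 3 (0.02 log units; within the scatter). Within the data shown here, compound 1 carries the incoming 2-fluoro-4-(trifluoromethyl)phenyl, but on a different core, so no measured pair isolates this group. The expected change in this assay is therefore a 1.1-fold higher number from compound 3 to compound 4 (0.06 log units; within the scatter), nothing beyond the scatter. For compound 4 the estimated value is 32000 nM, with an expected range from 14000 nM to 75000 nM.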

Compound 4, concentration for 50% growth inhibition: 100000 nM
Estimate against measurement, compound 4: 3.1-fold (0.49 log units) below; measured number above the stated range.
By their numbers in this assay, from the lowest: compounds 2 and 3 (each within the scatter of the next); then compounds 1 and 4 (each within the scatter of the next).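

In this assay, 2-fluoro-4-(trifluoromethyl)phenyl weakens growth inhibition compared with either dichlorophenyl group, giving a 3.6-fold higher number from compound 3 to compound 4 (0.55 log units; beyond the scatter) and a 3.7-fold higher number from compound 2 to compound 4 (0.57 log units; beyond the scatter), so this place does respond to the group it carries, which the two dichlorophenyl compounds alone did not show. With this group in place, bromo in place of hydrogen on an aromatic carbon gives no change at the digits printed from compound 1 to compound 4 (within the scatter), so this pair shows no effect of the bromo. No available evidence explains the weaker inhibition.

The compounds shown leave open whether the trifluoromethyl or the fluoro accounts for the step. Going by these compounds, how a phenyl group carrying an amine or a carboxylic acid would read at this place also remains open.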